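Compound 3 to compound 4: chloro for carboxy

The compounds below may be only part of what the source reports. "The series", "measured", "known", "first", "only" and "open" are said of these compounds alone.

In an ADME assay on BJ cells (Homo sapiens) for cytotoxicity, with a stated time of 72 h (a higher number here means that more compound is needed for the effect, a lower number that less compound is needed), compound 3 (`Cc1cc(NC(=O)Nc2ccc(C(=O)O)cc2)c2ccccc2n1`) reads > 25000 nM as a limit of the assay. Compound 1 (`Cc1ccc(NC(=O)Nc2cc(C)nc3ccccc23)cc1`) reads > 25000 nM in this assay and this is also a limit. Among the measured compounds shown here, compound 2 (`COC(=O)c1ccc(NC(=O)Nc2cc(C)nc3ccccc23)cc1`) gives a measured number in this assay of 21000 nM as the only value that is not a limit.

The change to compound 4 (`Cc1cc(NC(=O)Nc2ccc(Cl)cc2)c2ccccc2n1`) is chloro in place of carboxy on an aromatic carbon, para to a large group (chloro in place of carboxy on an aromatic carbon). Chloro has no measured precedent in the series, so the nearest guidance comes from the other steps. Methoxycarbonyl in place of methyl gives an at least 1.1-fold lower number from compound 1 to compound 2 (0.07 log units; that floor lies within the scatter) and carboxy in place of methyl gives a step that the two limits leave unreadable from compound 1 to compound 3 in the same assay. Hydrogen in place of methyl on an oxygen next to a carbonyl group gives an at least 1.1-fold higher number from compound 2 to compound 3 (0.07 log units; that floor lies within the scatter) as the third step. None of these steps is shown to lie beyond the scatter, so no clear step is expected in this assay. A slight lean to a lower number rests only on compound 2 (21000 nM). The expected step is an estimate (an at least 1.4-fold lower number from compound 3 to compound 4 (0.16 log units; that floor lies within the scatter)). For compound 4 the estimated value is 17000 nM with an expected range from 6000 nM to 30000 nM as the working figure.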

Compound 4, half-maximal effective concentration: > 25000 nM
Compound 4 ended at the assay's limit; the forecaster's own chance of this, stated with the estimate: 50%; at least 1.4-fold (0.16 log units) between middle value and limit.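

In this assay, chloro on this aromatic carbon, para to a large group, ends at the same limit as methyl and carboxy, so three quite different groups at this position now share it: the limit of > 25000 nM in this assay, at which 3 of the 4 values shown sit.

The one readable step is an at least 1.1-fold higher number from compound 2 to compound 4 (0.07 log units; that floor lies within the scatter), so chloro in place of methoxycarbonyl is not shown to move the number, and compound 2 is not set apart from compound 4 by this result. The steps from compound 3 and from compound 1 to compound 4 cannot be read, as both ends of each are limits.

How far the true values of compound 1, compound 3 and compound 4 lie past the limit stays open, and with it any order among these three. Also open, on these data alone, is whether an amine or a longer chain at this position would give a number clearly lower than the limit, by a step beyond the scatter.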